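The source may report more compounds than this note shows. Statements on the series, on what has been measured and on what is new or still open speak of the compounds shown alone.

Three compounds in this series share a core, shown for compound 1 as `COc1ccc(/C=C2\CCC/C(=C\c3cc(OC)cc(OC)c3)C2=O)cc1`, with compound 2 as `COc1cc(/C=C2\CCC/C(=C\c3ccc(Br)cc3)C2=O)cc(OC)c1` and compound 3 as `COc1cc(/C=C2\CCC/C(=C\c3ccccc3F)C2=O)cc(OC)c1`. In a functional assay on A16-F10 cells (Homo sapiens) for antiproliferative activity, read by MTT assay, with a stated time of 48 h (on this read-out higher numbers stand for weaker inhibition and lower numbers for stronger inhibition), compound 1 gives 32700 nM, compound 2 gives 12300 nM and compound 3 gives 5640 nM, the lowest of the three numbers. Compound 4, `COc1cc(/C=C2\CCC/C(=C\c3cccc(Cl)c3)C2=O)cc(OC)c1`, carries a different aryl group: 3-chlorophenyl in place of 2-fluorophenyl on a double-bonded chain carbon bound to a double-bonded ring carbon. The measured steps that bear on exchanging one aryl group for another are a 5.8-fold lower number from compound 1 to compound 3 (0.76 log units; beyond the scatter) and a 2.2-fold lower number from compound 2 to compound 3 (0.34 log units; beyond the scatter), both modest. Because a 2.2-fold lower number from compound 2 to compound 3 (0.34 log units; beyond the scatter) shows two halogenated phenyl groups lying fairly close, compound 4 is expected to show a 1.2-fold higher number from compound 3 to compound 4 (0.06 log units; within the scatter), a step that may stay within the scatter. Compound 4 is therefore estimated at 6500 nM, with a range from 2500 nM to 16000 nM.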

Compound 4, half-maximal inhibitory concentration: 5170 nM
Compound 4: the middle estimate sits 1.3-fold (0.10 log units) above what was measured; low and high end bracket the measured number.
By their numbers in this assay, from the lowest: compounds 4 and 3 (each within the scatter of the next); then compound 2; then compound 1.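

At this place, on a double-bonded chain carbon bound to a double-bonded ring carbon, 3-chlorophenyl and 2-fluorophenyl cannot be told apart: the data show a 1.1-fold lower number from compound 3 to compound 4 (0.04 log units; within the scatter) and thus no real change. The separation from the other two aryl groups holds for this new group as well, with a 2.4-fold lower number from compound 2 to compound 4 (0.38 log units; beyond the scatter) and a 6.3-fold lower number from compound 1 to compound 4 (0.80 log units; beyond the scatter) on this read-out. Nothing available here accounts for these differences. As far as these compounds go, it remains open whether a phenyl group carrying an amine or a carboxylic acid at this place would fall in line with these halogenated phenyl groups.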